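From compound 3 to compound 4: one more methyl

This account rests on a few compounds, and the source may have more. Where it says the series, first, only, none or still open, it means among the compounds named here.

Values so far in a functional assay on MCF7 cells (Homo sapiens) for inhibition, read by CCK-8 assay, with a stated time of 72 h (on this read-out higher numbers stand for weaker inhibition and lower numbers for stronger inhibition), for three compounds
- compound 1 `O=C(/C=C/c1cccnc1)NCCCCCCc1cccc(S(=O)(=O)Nc2ccccc2)c1` gives 0.63 nM
- compound 2 `Cc1ccc(NS(=O)(=O)c2cccc(CCCCCCNC(=O)/C=C/c3cccnc3)c2)cc1` gives 1.97 nM
- compound 3 `Cc1cccc(NS(=O)(=O)c2cccc(CCCCCCNC(=O)/C=C/c3cccnc3)c2)c1` gives 4 nM

Compound 3 gives the highest number of the three, with 4 nM as its value, and so is the weakest of them. Compound 4 `Cc1ccc(C)c(NS(=O)(=O)c2cccc(CCCCCCNC(=O)/C=C/c3cccnc3)c2)c1` differs from it by methyl in place of hydrogen on an aromatic carbon and so turns the 3-methylphenyl into 2,5-dimethylphenyl. Two measured steps made the same kind of change, a methyl in place of hydrogen on an aromatic carbon. They are a 3.1-fold higher number from compound 1 to compound 2 (0.50 log units; beyond the scatter) and a 6.3-fold higher number from compound 1 to compound 3 (0.80 log units; beyond the scatter) and both are modest rises. Moving the methyl alone gave a 2.0-fold higher number from compound 2 to compound 3 (0.31 log units; beyond the scatter) as a further step. Neither methyl in those compounds sits ortho to a large group, so the comparison is incomplete. A modest rise is therefore expected again in this assay with a wide margin. The estimate amounts to an expected 2.3-fold higher number from compound 3 to compound 4 (0.35 log units; beyond the scatter) in this series. For compound 4 the estimated value is 9 nM within an expected range of 3 nM to 27 nM on this read-out.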

Compound 4, half-maximal inhibitory concentration: 0.6 nM
Compound 4: middle estimate off by 15-fold (1.18 log units), on the high side; measured number outside the range, below it.
By their numbers in this assay, from the lowest: compounds 4 and 1 (each within the scatter of the next); then compound 2; then compound 3.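

In this assay, a methyl ortho to a large group does not act as the earlier methyls did: it gives a 6.7-fold lower number from compound 3 to compound 4 (0.82 log units; beyond the scatter), so the same kind of change can lower the number as well as raise it, depending on the ring it is added to: the same change on two cores in this assay, a 3.1-fold higher number (0.50 log units; beyond the scatter) from compound 1 to compound 2 and a 6.7-fold lower number (0.82 log units; beyond the scatter) from compound 3 to compound 4, 21-fold (1.32 log units) apart, beyond the scatter of two such steps The 2,5-dimethylphenyl group in place of 4-methylphenyl gives a 3.3-fold lower number from compound 2 to compound 4 (0.52 log units; beyond the scatter). In place of phenyl it gives a 1.1-fold lower number from compound 1 to compound 4 (0.02 log units; within the scatter), so on this read-out a ring carrying two methyls can stand level with the plain phenyl.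

The compounds shown hold this methyl only together with the methyl para to it, so what it does on a phenyl ring without that second methyl stays open. From the compounds shown here alone, whether an ethyl or a methoxy group at the same place would act alike also stays open.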